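Returning to a thiophen-2-yl, now carrying a methyl

A few compounds are considered here, and "the series" means these few. Any claim that something is new, unique, unknown or untested is made for them only; others in the source may bear on it.

Measured in a functional assay for activation of Alpha-1B adrenergic receptor (Homo sapiens), read by calcium flux; on this read-out lower numbers stand for an effect already at smaller amounts and higher numbers for an effect only at larger amounts of compound:
- compound 1 `c1csc(-c2ccccc2OCC2=NCCN2)c1` gives 3.98 nM
- compound 2 `c1ccc(-c2ccoc2)c(OCC2=NCCN2)c1` gives 5.01 nM
- compound 3 `c1ccc(-c2ccsc2)c(OCC2=NCCN2)c1` gives 15.9 nM

Compound 3 stands highest of the three numbers in this assay, with a 3.2-fold higher number from compound 2 to compound 3 (0.50 log units; beyond the scatter) and a 4.0-fold higher number from compound 1 to compound 3 (0.60 log units; beyond the scatter) both beyond the scatter. Compound 4 `Cc1ccc(-c2ccccc2OCC2=NCCN2)s1` differs from compound 3 by 5-methylthiophen-2-yl in place of thiophen-3-yl on an aromatic carbon. Within the data shown here, the step that bears on this is the one from compound 1 to compound 3, where a 4.0-fold higher number from compound 1 to compound 3 (0.60 log units; beyond the scatter); the present change runs the opposite way on the ring attachment but adds a methyl, for which no measured pair exists. Compound 4 is therefore expected to return toward compound 1, an estimated 3.2-fold lower number from compound 3 to compound 4 (0.50 log units; beyond the scatter) in this assay. The estimate for compound 4 is 5 nM, with a range from 1.5 nM to 16 nM.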

Compound 4, half-maximal effective concentration: < 100000 nM
Compound 4: no number, only a limit; the forecaster's own chance of this, stated with the estimate: 2%; the middle value does not contradict the limit.
By their numbers in this assay, from the lowest: compounds 1 and 2 (each within the scatter of the next); then compound 3.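

In this assay compound 4 gives < 100000 nM, a limit and not a number. Among these compounds, no step from compound 1, compound 2 or compound 3 to compound 4 can be read. The compounds shown leave open how 5-methylthiophen-2-yl compares with thiophen-2-yl in this assay.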